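Moving the chlorine on the anilide: compound 3 to compound 4

A few compounds are considered here, and "the series" means these few. Any claim that something is new, unique, unknown or untested is made for them only; others in the source may bear on it.

compound 1 `CC(=O)SCCC(CCCCC(=O)Nc1ccc(Cl)cc1)SC(C)=O`: 58.8%
compound 2 `O=C(CCCCC(CCSC(=O)c1ccccc1)SC(=O)c1ccccc1)Nc1ccccc1`: "not active" (no number reported)
compound 3 `O=C(CCCCC(CCSC(=O)c1ccccc1)SC(=O)c1ccccc1)Nc1ccccc1Cl`: "not active" (no number reported)

All three entries come from a functional assay on HO8910 cells (Homo sapiens) for inhibition, read by MTT assay, with a stated time of 24 h, tested at 100 ug/mL; a higher number here means more inhibition of growth at the concentration tested, a lower number less inhibition of growth. Compound 3 has no single number there and is reported only as "not active" (no number reported), the same outcome as for compound 2. The sole numerical result in the series belongs to compound 1.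

The next structure is compound 4 `O=C(CCCCC(CCSC(=O)c1ccccc1)SC(=O)c1ccccc1)Nc1ccc(Cl)cc1`. The change is 4-chlorophenyl in place of 2-chlorophenyl on an amide-type nitrogen, so 4-chlorophenyl takes the place of 2-chlorophenyl on an amide-type nitrogen, and the rest of the structure stays the same.

For the measured compounds named here, no measured pair isolates this change, so the series gives no direct size for the step. Compound 1 carries the same 4-chlorophenyl and gives 58.8%, but it also differs from compound 4 elsewhere in its structure, so it is only a loose guide. Compound 2 and compound 3 are closer to compound 4 and offer no number. A modest upward step from compound 3 in this assay is therefore expected, though another report without a number remains quite possible. The estimated value for compound 4 is 20%, with an expected range from 0% to 50%.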

Compound 4, percent growth inhibition at one concentration: "not active" (no number reported)
Compound 4: no number reported; there is nothing to compare the estimate with.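

In this assay compound 3 and compound 4 are both reported only as "not active", with no number, so no step can be read between them. The compounds shown leave open whether 2-chlorophenyl and 4-chlorophenyl on the amide-type nitrogen differ at all on the shared core. No measured evidence bears on this result.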